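The compounds below may be only part of what the source reports. "The series", "measured", "known", "first", "only" and "open" are said of these compounds alone.

In a functional assay (trachea) with Cavia porcellus as the target (on this read-out higher numbers stand for weaker inhibition and lower numbers for stronger inhibition), three compounds sharing one core have been measured, and they differ only in the group on an aromatic nitrogen. Compound 1 (`CC(C)n1nc(-c2cccnc2)c2ccccc2c1=O`) gives 3090 nM and compound 2 (`C=CCn1nc(-c2cccnc2)c2ccccc2c1=O`) gives 2140 nM on this read-out. Compound 3 (`O=c1c2ccccc2c(-c2cccnc2)nn1Cc1cccc(Cl)c1`) gives 4170 nM and stands within the scatter of both others, as a 1.3-fold higher number from compound 1 to compound 3 (0.13 log units; within the scatter) and a 1.9-fold higher number from compound 2 to compound 3 (0.29 log units; within the scatter) show.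

Compound 4 (`O=C(c1cccs1)n1nc(-c2cccnc2)c2ccccc2c1=O`) carries (thiophen-2-yl)carbonyl in place of 3-chlorobenzyl on an aromatic nitrogen is the whole of the change from compound 3.

The measured steps that bear on this are the exchanges at the same nitrogen. Those two steps and a 1.4-fold lower number from compound 1 to compound 2 (0.16 log units; within the scatter) all stay small, so isopropyl, allyl and 3-chlorobenzyl cannot be told apart on these numbers. For the measured compounds named here, the entering group, however, has no counterpart among the measured compounds, so these three steps give only weak guidance and the range must stay wide. No step beyond the scatter is therefore expected, and no direction can be favoured. The expected change is a 1.2-fold lower number from compound 3 to compound 4 (0.08 log units; within the scatter) in this assay on this reasoning. For compound 4 the estimated value is 3500 nM with an expected range from 1100 nM to 11000 nM on the same read-out.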

Compound 4, half-maximal inhibitory concentration: 12300 nM
Compound 4: the middle estimate sits 3.5-fold (0.55 log units) below what was measured; measured number above the stated range.
By their numbers in this assay, from the lowest: compounds 2, 1 and 3 (each within the scatter of the next); then compound 4.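

For the compounds shown here, at the aromatic nitrogen, where isopropyl, allyl and 3-chlorobenzyl could not be told apart in this assay, (thiophen-2-yl)carbonyl is the first group to move the number beyond the scatter (a 2.9-fold higher number from compound 3 to compound 4 (0.47 log units; beyond the scatter)), and the same holds against the other two groups (a 4.0-fold higher number from compound 1 to compound 4 (0.60 log units; beyond the scatter); a 5.7-fold higher number from compound 2 to compound 4 (0.76 log units; beyond the scatter)). All three steps are modest and run the same way, toward weaker inhibition, so this position is not indifferent to every group placed on it, even though the three earlier groups, including both small chains and a benzyl group, gave numbers within the scatter of one another. Nothing available explains the rise, and the change from 3-chlorobenzyl brings a carbonyl onto the nitrogen and a five-membered aromatic ring at once.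

The compounds shown do not separate the carbonyl from the thiophene ring, which a benzoyl group or a (thiophen-2-yl)methyl group on the same nitrogen could do. Also open, from the compounds shown here alone, is whether any group there gives a clearly lower number, for instance a longer chain ending in an amine or a carboxylic acid, and what a change to the pyridin-3-yl group would do.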